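A few compounds are considered here, and "the series" means these few. Any claim that something is new, unique, unknown or untested is made for them only; others in the source may bear on it.

Three compounds share one core, a sulfonamide joined through a short chain to an amine that carries an arylmethyl group. In a functional assay on HPAC cells (Homo sapiens) for inhibition, read by MTT assay, with a stated time of 72 h (a higher number here means a weaker inhibitor of growth, a lower number a stronger inhibitor of growth), compound 1 `O=S(=O)(NCCNCc1cccc2ccccc12)c1cc(C(F)(F)F)cc(C(F)(F)F)c1` gives 18000 nM, compound 2 `CC(C)(C)c1ccc(CNCCCNS(=O)(=O)c2cc(C(F)(F)F)cc(C(F)(F)F)c2)cc1` gives 2300 nM, and compound 3 `COc1ccc(CNCCCNS(=O)(=O)c2cc(C(F)(F)F)cc(C(F)(F)F)c2)cc1OC` gives 3500 nM, the second highest of the three numbers, close to compound 2 and well apart from compound 1, which differs in both the chain and the aryl group. Going by the values given here, the only step that bears on the aryl group alone, a 1.5-fold higher number from compound 2 to compound 3 (0.18 log units; within the scatter), was small. Compound 4 `O=S(=O)(NCCCNCc1ccccc1)c1cc(C(F)(F)F)cc(C(F)(F)F)c1` brings (phenyl in place of 3,4-dimethoxyphenyl on a saturated chain carbon bound to an amine nitrogen). Since the step of a 1.5-fold higher number from compound 2 to compound 3 (0.18 log units; within the scatter) stayed within the scatter, no large shift is expected here. Compound 4 is therefore estimated at 6000 nM, with a range from 2500 nM to 15000 nM. The expected step is a 1.7-fold higher number from compound 3 to compound 4 (0.23 log units; within the scatter).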

Compound 4, concentration for 50% growth inhibition: 3200 nM
Estimate against measurement, compound 4: 1.9-fold (0.27 log units) above; low and high end bracket the measured number.
By their numbers in this assay, from the lowest: compounds 2, 4 and 3 (each within the scatter of the next); then compound 1.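

Replacing 3,4-dimethoxyphenyl with plain phenyl gives a 1.1-fold lower number from compound 3 to compound 4 (0.04 log units; within the scatter) in this assay, and replacing tert-butyl with hydrogen gives a 1.4-fold higher number from compound 2 to compound 4 (0.14 log units; within the scatter). At this place, on a saturated chain carbon bound to an amine nitrogen, the phenyl ring therefore needs neither the two methoxy groups nor the tert-butyl group to stay within the scatter of the substituted compounds. No supporting measurement bears on why these changes make so little difference.

Going by these compounds, whether an amine or a carboxylic acid on the phenyl ring would shift the number remains open. So does how much of the gap to compound 1 comes from its chain and how much from its aryl group.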